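The source may hold more compounds than are shown below. What is called first, only, known or untested is meant among the compounds shown, and "the series" means these compounds.

Compound 1: `Clc1ccc(CO/N=C/c2c(-c3ccc4ccccc4c3)nc3sccn23)cc1Cl` – in an assay on HepG2 cells for agonist activity at nuclear receptor subfamily 1 group I member 3 (Homo sapiens), read by a luciferase reporter, with a stated time of 23 h (a lower number here means that less compound is needed, a higher number that more compound is needed for the effect), compound 1 gives 380 nM.
Compound 2: `CCc1nc2sccn2c1/C=N/OCc1ccc(Cl)c(Cl)c1` – in this assay compound 2 gives 2600 nM.
Compound 3: `Fc1ccc(-c2nc3sccn3c2/C=N/OCc2ccc(Cl)c(Cl)c2)cc1` – in this assay compound 3 gives 670 nM.

All three share one core and a dichlorobenzyl oxime ether and differ only in the group on one aromatic carbon. Compound 3 has the second highest of the three numbers: it lies nearest to compound 1, a gap that is within the scatter, and furthest from compound 2, a gap that is beyond it (a 3.9-fold lower number from compound 2 to compound 3 (0.59 log units; beyond the scatter)).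

Compound 4 is `COc1ccc(-c2nc3sccn3c2/C=N/OCc2ccc(Cl)c(Cl)c2)cc1`. It differs from compound 3 in this way: methoxy in place of fluoro on an aromatic carbon.

The measured steps all concern the group on the core itself: a 6.8-fold higher number from compound 1 to compound 2 (0.84 log units; beyond the scatter) and a 1.8-fold higher number from compound 1 to compound 3 (0.25 log units; within the scatter). Among the compounds with values here, no measured step changes a substituent on the phenyl ring, so the data give no direct guide for this change. Since the two aryl groups gave numbers within the scatter of each other, compound 4 is expected to stay close to compound 3, a step of a 1.1-fold lower number from compound 3 to compound 4 (0.05 log units; within the scatter), with an estimate of 600 nM in this assay, between 250 nM and 1500 nM.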

Compound 4, half-maximal effective concentration: 490 nM
The estimate for compound 4 lay 1.2-fold (0.09 log units) above the measured number, within the range that was stated.
By their numbers in this assay, from the lowest: compounds 1, 4 and 3 (each within the scatter of the next); then compound 2.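

In this assay, within the data shown here, the step from fluoro to methoxy on the phenyl ring (a 1.4-fold lower number from compound 3 to compound 4 (0.14 log units; within the scatter)) is the first to change this position, para to a large group, and it leaves the number within the scatter. The 4-methoxyphenyl group also stays within the scatter of naphthalen-2-yl (a 1.3-fold higher number from compound 1 to compound 4 (0.11 log units; within the scatter)) and, like the other two aryl groups, is clearly separated from ethyl (a 5.3-fold lower number from compound 2 to compound 4 (0.72 log units; beyond the scatter)), so this separation now holds for all three aryl groups shown. No measurement at hand bears on why these numbers fall as they do.

Whether the same tolerance extends to an amine or a carboxylic acid at this position remains open, since fluoro and methoxy are the only two groups shown there. Also open, as far as these compounds go, is how a longer chain in place of ethyl on the core would compare, and whether the dichlorobenzyl oxime ether can be changed at all.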